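The compounds below may be only part of what the source reports. "The series", "measured", "known", "first", "only" and "open" are said of these compounds alone.

In an ADME assay (liver) for metabolic stability, with Liver microsome (Rattus norvegicus) as the target, using microsomes and NADPH, with a stated time of 30 min, tested at 1 uM (a higher number here means faster removal of the compound, a lower number slower removal), three compounds have been measured:

compound 1, `Nc1ccc(S(=O)(=O)N2CCN(c3ncc(C(O)(C(F)(F)F)C(F)(F)F)cc3Br)CC2)cn1`, gives 32 mL.min-1.g-1
compound 2, `CC(C)(C)n1cc(-c2cc(C(O)(C(F)(F)F)C(F)(F)F)cnc2N2CCN(S(=O)(=O)c3ccc(N)nc3)CC2)cn1`, gives 459 mL.min-1.g-1
compound 3, `CS(=O)(=O)c1ccc(-c2cc(C(O)(C(F)(F)F)C(F)(F)F)cnc2N2CCN(S(=O)(=O)c3ccc(N)nc3)CC2)cc1`, gives 103 mL.min-1.g-1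

Compound 3 stands second highest of the three. Its nearest neighbour is compound 1, and the step of a 3.2-fold higher number from compound 1 to compound 3 (0.51 log units; beyond the scatter) is modest; its furthest is compound 2, and the step of a 4.5-fold lower number from compound 2 to compound 3 (0.65 log units; beyond the scatter) is also modest. Compound 4, `Nc1ccc(S(=O)(=O)N2CCN(c3ncc(C(O)(C(F)(F)F)C(F)(F)F)cc3-c3cc4ccccc4[nH]3)CC2)cn1`, differs from compound 3 in one place: 1H-indol-2-yl in place of 4-(methylsulfonyl)phenyl on an aromatic carbon.

Among the compounds with values here, the steps that bear on this change are the two that alter the same position: a 3.2-fold higher number from compound 1 to compound 3 (0.51 log units; beyond the scatter) and a 14-fold higher number from compound 1 to compound 2 (1.16 log units; beyond the scatter). Both show that a larger group at this position gives a higher number than bromo, and the aromatic 1-(tert-butyl)-1H-pyrazol-4-yl gives the highest number of the three. The 1H-indol-2-yl that enters is a larger aromatic group with one hydrogen-bond donor and no acceptor, so a modest rise beyond the scatter is expected, with the direction more certain than the size. For compound 4 the number in this assay is estimated at 250 mL.min-1.g-1, expected between 90 mL.min-1.g-1 and 650 mL.min-1.g-1, a step of a 2.4-fold higher number from compound 3 to compound 4 (0.39 log units; beyond the scatter).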

Compound 4, intrinsic clearance in microsomes: 146 mL.min-1.g-1
Estimate against measurement, compound 4: 1.7-fold (0.23 log units) above; measured number inside the range.
By their numbers in this assay, from the lowest: compound 1; then compounds 3 and 4 (each within the scatter of the next); then compound 2.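

In this assay, replacing 4-(methylsulfonyl)phenyl with 1H-indol-2-yl gives a 1.4-fold higher number from compound 3 to compound 4 (0.15 log units; within the scatter) and so leaves the read-out unresolved, even though the two groups differ in their rings and in their counts of hydrogen-bond donors and acceptors. Compound 2 remains apart, with a 3.1-fold lower number from compound 2 to compound 4 (0.50 log units; beyond the scatter) for the change from 1-(tert-butyl)-1H-pyrazol-4-yl to 1H-indol-2-yl, so not every aromatic group at this carbon gives the same result. With a 4.6-fold higher number from compound 1 to compound 4 (0.66 log units; beyond the scatter) as a third step from bromo, all three aromatic groups shown give a higher number than bromo, and none of the compounds goes against this.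

Nothing here gives a reason for these differences. Going by these compounds, it remains open whether an amine or a carboxylic acid at this carbon would give a number near that of compound 1 or near those of the aromatic groups.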